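A few compounds are considered here, and "the series" means these few. Any claim that something is new, unique, unknown or untested is made for them only; others in the source may bear on it.

Measured compounds:
- compound 1, `CC(C)c1ccc(-c2nc(SCc3cn(CC(=O)NC(=O)Nc4ccccn4)nn3)nc(Nc3ccc(F)cc3)c2C#N)cc1`, 7250 nM
- compound 2, `CC(C)c1ccc(-c2nc(SCc3cn(CC(=O)NC(=O)Nc4ccccn4)nn3)nc(Nc3cccc(Cl)c3)c2C#N)cc1`, 1130 nM
- compound 3, `CC(C)c1ccc(-c2nc(SCc3cn(CC(=O)NC(=O)Nc4ccccn4)nn3)nc(Nc3ccccc3)c2C#N)cc1`, 14300 nM

Of the compounds shown here, three sharing one core have been tested in a functional assay on B16-F10 cells (Mus musculus) for inhibition, read by MTT assay, with a stated time of 72 h; on this read-out lower numbers stand for stronger inhibition and higher numbers for weaker inhibition. Among them compound 1 gives the second highest number of the three: compound 2 sits well away from it, with a 6.4-fold lower number from compound 1 to compound 2 (0.81 log units; beyond the scatter), whereas compound 3 sits close to it, with a 2.0-fold higher number from compound 1 to compound 3 (0.29 log units; within the scatter). Compound 2 and compound 3 are separated more widely, with a 13-fold higher number from compound 2 to compound 3 (1.10 log units; beyond the scatter).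

Compound 4, `Cc1ccccc1Nc1nc(SCc2cn(CC(=O)NC(=O)Nc3ccccn3)nn2)nc(-c2ccc(C(C)C)cc2)c1C#N`, differs from compound 1 in one place: 2-methylphenyl in place of 4-fluorophenyl on a nitrogen on an aromatic ring. Within the data shown here, no measured step tests a 2-methylphenyl group, so the bearing steps are only indirect. The step from compound 1 to compound 3 removes the fluoro and changes little; the step from compound 1 to compound 2 brings in a 3-chlorophenyl and lowers the number substantially. A methyl group on the ring at a different place could go either way, and nothing in the measured data fixes its effect. A step of modest size, in no firmly predicted direction, is therefore expected, and compound 4 is estimated to give 8000 nM, within a range of 2500 nM to 25000 nM, corresponding to a 1.1-fold higher number from compound 1 to compound 4 (0.04 log units; within the scatter).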

Compound 4, half-maximal inhibitory concentration: 18600 nM
Estimate against measurement, compound 4: 2.3-fold (0.37 log units) below; the measured number falls inside the stated range.
By their numbers in this assay, from the lowest: compound 2; then compounds 1, 3 and 4 (each within the scatter of the next, the first and the last beyond it).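

In this assay, placing a methyl on the ring of compound 3 gives a 1.3-fold higher number from compound 3 to compound 4 (0.11 log units; within the scatter), so this 2-methylphenyl group cannot be told apart from the plain phenyl ring on that nitrogen. The swap from the 4-fluorophenyl group gives a 2.6-fold higher number from compound 1 to compound 4 (0.41 log units; beyond the scatter), while the swap from the 3-chlorophenyl group gives a 16-fold higher number from compound 2 to compound 4 (1.22 log units; beyond the scatter), which leaves compound 2 as the only one of the four standing clearly apart, with the lowest number, and shows that a substituent on this ring does not by itself bring the number down. Nothing available explains why the 3-chlorophenyl group stands apart from the 2-methylphenyl group.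

The four compounds cannot show whether the low number of compound 2 belongs to chloro in particular or would also appear with another group on the ring, such as a methoxy group, a bromo group or a trifluoromethyl group. They also leave open how a group of a different kind on this ring, such as an amine or a carboxylic acid, would shift the number.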